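Enantiomer swap at the chain stereocentre, compound 3 to compound 4

This account rests on a few compounds, and the source may have more. Where it says the series, first, only, none or still open, it means among the compounds named here.

Measured in an assay for positive allosteric modulation of metabotropic glutamate receptor 3 (Rattus norvegicus); on this read-out higher numbers stand for an effect only at larger amounts of compound and lower numbers for an effect already at smaller amounts:
compound 1 `Cc1c(OCCCCOc2ccc(C(=O)O)c(F)c2)ccc(C(=O)CC(C)(C)C)c1O` gives 1110 nM
compound 2 `Cc1c(OC[C@@H](C)Oc2ccc(F)c(C(=O)O)c2)ccc(C(=O)CC(C)(C)C)c1O` gives 1210 nM
compound 3 `COc1ccc(C(=O)O)cc1O[C@@H](C)COc1ccc(C(=O)CC(C)(C)C)c(O)c1C` gives 2210 nM

Compound 3 carries the highest of the three numbers in this assay, but its gap to compound 2 and its gap to compound 1 both stay within the usual scatter, so the three measured compounds are not separated from one another on this read-out.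

Compound 4 `COc1ccc(C(=O)O)cc1O[C@H](C)COc1ccc(C(=O)CC(C)(C)C)c(O)c1C` has not been measured. Compared with compound 3, the two compounds have the same atoms and bonds and differ only in configuration as drawn: 1 of 1 stereo elements differ; a stereocentre at a saturated chain carbon is drawn S in compound 3 and R in compound 4: the two compounds have the same atoms and bonds and differ only in configuration as drawn, one stereo element at a saturated chain carbon.

Within the data shown here, no pair of measured compounds differs by a stereocentre alone, so nothing shows what inverting this centre does. Compound 2 also carries a stereocentre in this chain, with a value near that of compound 3, but it has a different acid-bearing ring and is not a guide. The expectation for compound 4 is therefore a step of a 1.0-fold lower number from compound 3 to compound 4 (0.00 log units; within the scatter) with no direction beyond the scatter, and a wide range on either side. Compound 4 is estimated at 2200 nM in this assay, with a range from 700 nM to 7000 nM.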

Compound 4, half-maximal effective concentration: 1850 nM
Estimate against measurement, compound 4: 1.2-fold (0.08 log units) above; the range from low to high includes it.
By their numbers in this assay, from the lowest: compounds 1, 2, 4 and 3 (each within the scatter of the next).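

In this assay, among these compounds, inverting the stereocentre at the saturated chain carbon gives a 1.2-fold lower number from compound 3 to compound 4 (0.08 log units; within the scatter), the first step that isolates this centre. The comparison reads as one of configuration alone: the fact that compounds 3 and 4 differ only in the configuration as drawn. Among the compounds shown here, with this methoxy-bearing acid ring, the S and R forms as drawn are not separated on this read-out, so inverting the centre gives no measurable difference in either direction, something the earlier compounds, which differ in more than one place, could not show.

Open, as far as these compounds go, is whether the two configurations also stay unseparated with the fluorine-bearing acid ring of compound 2. Also open, from the compounds shown here alone, is what an ethyl group in place of the methyl at this chain carbon, or an amide in place of the carboxylic acid, would do on this read-out.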